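A few compounds are considered here, and "the series" means these few. Any claim that something is new, unique, unknown or untested is made for them only; others in the source may bear on it.

The measured compounds, each with its largest response in a functional assay on isolated protein for inhibition of Glucose-dependent insulinotropic receptor (Rattus norvegicus), read by HTRF and cAMP accumulation; on this read-out higher numbers stand for larger maximal responses and lower numbers for smaller maximal responses:

compound 1, `Cc1nc(S(C)(=O)=O)ccc1Oc1ncnc(OC2CCN(C(=O)O[C@H](C)CF)CC2)c1F`, gives 79%
compound 2, `Cc1nc(S(C)(=O)=O)ccc1Oc1ncnc(OC2CCN(C(=O)O[C@@H](C)C(F)(F)F)CC2)c1F`, gives 80%
compound 3, `Cc1nc(S(C)(=O)=O)ccc1Oc1ncnc(OC2CCN(C(=S)OC3(C)CC3)CC2)c1F`, gives 49%

Compound 3 stands lowest of the three; the gap to compound 1 and to compound 2 is beyond the scatter, while compound 1 and compound 2 lie within the scatter of each other.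

Compound 4, `Cc1nc(S(C)(=O)=O)ccc1Oc1ncnc(OC2CCN(C(=O)c3nc(C(C)(C)F)no3)CC2)c1F`, differs from compound 3 in one place: a group of 11 heavy atoms (6 carbon, 2 nitrogen, 2 oxygen, 1 fluorine; one five-membered aromatic ring with 3 hetero atoms) in place of a group of 7 heavy atoms (5 carbon, 1 oxygen, 1 sulfur; one three-membered non-aromatic ring of carbon only), on an amine nitrogen in a ring

Among the compounds with values here, two measured steps bear on this change. Both concern the very group that now leaves. It entered in a number 30 percentage points lower from compound 1 to compound 3 (beyond the scatter) and in a number 31 percentage points lower from compound 2 to compound 3 (beyond the scatter), and in each case the response fell. Removing it again is therefore expected to lift the response, though the entering group is unlike either of the two groups it replaced there, so the recovery is expected to be only partial and uncertain, a number 21 percentage points higher from compound 3 to compound 4 (beyond the scatter).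

Compound 4 is thus estimated at 70%, within a range from 52% to 88%.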

Compound 4, largest response reached (reported as efficacy), in percent of the reference or control that the assay uses: 84%
Compound 4: the middle estimate sits 14 percentage points below what was measured, and the stated range covers the measured number.
By their numbers in this assay, from the lowest: compound 3; then compounds 1, 2 and 4 (each within the scatter of the next).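

In this assay, placing the group with the five-membered aromatic ring on the amine nitrogen in place of the group with the three-membered carbon ring gives a number 35 percentage points higher from compound 3 to compound 4 (beyond the scatter) and shows that the low response of compound 3 does not extend to every ring-bearing group here. Set against the two open-chain fluorinated groups, the same ring gives a number 4 percentage points higher from compound 2 to compound 4 (within the scatter) and a number 5 percentage points higher from compound 1 to compound 4 (within the scatter) and so shows no separation from either. Among these four compounds, a ring at this position is therefore compatible with a large response, and compound 3 is the only one that falls away.

On these data alone, whether the sulfur or the three-membered ring of compound 3 goes with its lower response stays open, as does the result of an amine or a longer chain on the aromatic ring. Nothing available explains these responses.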